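This account rests on a few compounds, and the source may have more. Where it says the series, first, only, none or still open, it means among the compounds named here.

Three compounds of this series carry numbers in an assay on HEK293 cells for displacement of a labelled ligand from Melanocortin receptor 4 (Homo sapiens); on this read-out lower numbers stand for stronger inhibition and higher numbers for weaker inhibition. Compound 1 `CC(C)[C@H](NC(=O)CCN(C)C)c1cccc(F)c1N1CCN(C(=O)[C@@H]2CN(C(C)C)C[C@H]2c2cc(F)c(F)c(F)c2)CC1` gives 250 nM. Compound 2 `CCC(=O)N1C[C@@H](C(=O)N2CCN(c3ccc(C)cc3[C@@H](NC(=O)CCN(C)C)C(C)C)CC2)[C@H](c2ccc(Cl)cc2)C1` gives 4.6 nM. Compound 3 `Cc1ccc(N2CCN(C(=O)[C@@H]3CN(C4CCOCC4)C[C@H]3c3ccc(Cl)cc3)CC2)c([C@@H](NC(=O)CN)C(C)C)c1` gives 2 nM. On these numbers compound 2 stands second highest of the three: compound 3 is nearest, with a lower number that lies beyond the scatter, and compound 1 is furthest, with a much higher number, also beyond the scatter.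

Compound 4 `CC(=O)N1C[C@@H](C(=O)N2CCN(c3ccc(C)cc3[C@@H](NC(=O)CCN(C)C)C(C)C)CC2)[C@H](c2ccc(Cl)cc2)C1` has not yet been measured in this assay. It differs from compound 2 in one place: hydrogen in place of methyl on a saturated chain carbon bound to a carbonyl carbon, so propanoyl becomes acetyl. Among the compounds with values here, no pair of measured compounds shows this step, so there is no measured anchor for it. The change is confined to that chain, and the step of a 1.1-fold higher number from compound 2 to compound 4 (0.04 log units; within the scatter) is expected to stay within the scatter, with no preferred direction. Compound 4 is therefore expected near 5 nM, in a range from 2 nM to 13 nM.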

Compound 4, inhibition constant: 7.6 nM
For compound 4 the middle estimate is 1.5-fold (0.18 log units) below the measured one; the range from low to high includes it.
By their numbers in this assay, from the lowest: compound 3; then compounds 2 and 4 (each within the scatter of the next); then compound 1.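

In this assay, within the data shown here, propanoyl to acetyl now has a measured step (a 1.7-fold higher number from compound 2 to compound 4 (0.22 log units; within the scatter)), the first reading at this position, since the earlier compounds offered no pair with this change. Within the scatter, this read-out does not separate propanoyl from acetyl on the core shared by compound 2 and compound 4, so removing this methyl has no resolved effect on the number here. No measurement is available that would explain this outcome.

Still open, on these data alone, is whether a longer chain such as butanoyl, or an amine or a carboxylic acid in place of this methyl, would also stay within the scatter of compound 2. One pair also cannot show whether the same step reads alike with the other groups carried by compound 1 or compound 3.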